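The source may report more compounds than this note shows. Statements on the series, on what has been measured and on what is new or still open speak of the compounds shown alone.

Measured in a functional assay on Bel-7402 cells (Homo sapiens) for inhibition, read by MTT assay, with a stated time of 24 h, tested at 10 ug/mL; a lower number here means less inhibition of growth, a higher number more inhibition of growth at the concentration tested:
- compound 1 `O=C(CCCCC(S)CCS)NO`: 28.2%
- compound 2 `O=C(CCCCC1CCSS1)Nc1cccc(C(F)(F)F)c1`: 4.43%
- compound 3 `O=C(CCCCC(S)CCS)Nc1ccc(OC(F)(F)F)cc1`: 14.2%

Compound 1 stands highest of the three in this assay, beyond the scatter from both others. Compound 4 `O=C(CCCCC(S)CCS)Nc1ccccn1` has pyridin-2-yl in place of hydroxy on an amide-type nitrogen. Within the data shown here, no measured pair isolates this change, so the evidence is indirect. With the chain of compound 1 kept and the hydroxy replaced by a ring-bearing group, compound 3 gives 14.2%. A fall beyond the scatter is therefore expected, and the estimated step is a number 14.2 percentage points lower from compound 1 to compound 4 (beyond the scatter). For compound 4 the expected value is 14%, with an estimated range from 4% to 26%.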

Compound 4, percent growth inhibition at one concentration: "not active" (no number reported)
For compound 4 the study gives words and no number; there is nothing to compare the estimate with.
By their numbers in this assay, from the lowest: compounds 2 and 3 (each within the scatter of the next); then compound 1.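

Among these compounds, compound 4 is reported in this assay only as not active, without a number, so no step from compound 1 can be read. No measured evidence bears on this result. The compounds shown leave open what pyridin-2-yl in place of hydroxy alone does to growth inhibition.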